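The source may report more compounds than this note shows. Statements on the series, on what has been measured and on what is new or still open speak of the compounds shown alone.

Measured in a physicochemical assay, with a stated time of 30 min; a higher number here means that more compound is needed for the effect, a lower number that less compound is needed:
Compound 1 `C/C(=N/N=C1\SCC(=O)N1Cc1ccc(F)cc1)c1cccs1` gives 1850000 nM
Compound 2 `O=C1CS/C(=N\N=C2CCCC2)N1Cc1ccccc1F` gives 2370000 nM
Compound 3 `CC(C)=N/N=C1\SCC(=O)N1Cc1cccc([N+](=O)[O-])c1` gives 2350000 nM

These three values lie within the usual scatter of repeated measurements, so compound 2, at 2370000 nM, cannot be told apart from the other two compounds. The next compound to be tested is compound 4 `O=C1CS/C(=N\N=C2CCCC2)N1Cc1ccc(Cl)cc1`. It keeps the rest of compound 2 and changes one group: 4-chlorophenyl in place of 2-fluorophenyl on a saturated chain carbon bound to an amide-type nitrogen in a ring. In words, it has 4-chlorophenyl in place of 2-fluorophenyl on a saturated chain carbon bound to an amide-type nitrogen in a ring.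

Within the data shown here, no two measured compounds differ in only one place, so there is no direct precedent for this change. The best guide is the narrow spread overall. Compound 1 at 1850000 nM and compound 3 at 2350000 nM each differ from compound 2 in more than one place, yet remain within the scatter of it. In this assay, the expected step of a 1.1-fold lower number from compound 2 to compound 4 (0.05 log units; within the scatter) is therefore none beyond the scatter. For compound 4 the estimated value is 2100000 nM, with an expected range from 1200000 nM to 3600000 nM.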

Compound 4, half-maximal effective concentration: 2100000 nM
Compound 4: middle estimate and measured number agree at the digits printed; the measured number falls inside the stated range.
By their numbers in this assay, from the lowest: compounds 1, 4, 3 and 2 (each within the scatter of the next).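

In this assay, among these compounds, the step of a 1.1-fold lower number from compound 2 to compound 4 (0.05 log units; within the scatter) is the first comparison in this set that differs in only one place, so it isolates 4-chlorophenyl against 2-fluorophenyl on a saturated chain carbon bound to an amide-type nitrogen in a ring. Among the compounds shown here, with the rest of the structure held constant, these two groups cannot be told apart at this position, something the earlier compounds, which differ in more than one place, could not show. No measurement given here accounts for this result.

The exchange alters both the halogen and its ring position at once, so neither can be judged alone. From the compounds shown here alone, whether a carboxylic acid or an amine on the phenyl ring, or a longer chain in place of the single saturated carbon, would give a step beyond the scatter remains open.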